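Swapping the ring-nitrogen aryl group on a thiazolidinone scaffold

The compounds below may be only part of what the source reports. "The series", "measured", "known", "first", "only" and "open" are said of these compounds alone.

This account follows two compounds that share a core and one that has not yet been measured. Compound 1 `COc1ccccc1N1C(=O)CSC1c1cc(F)cc(C(=O)O)c1` carries a carboxylic acid on the pendant benzene and a 2-methoxyphenyl on the ring nitrogen; in a functional assay on HOS-TE85 cells (Homo sapiens) for inhibition, read by CCK-8 assay, with a stated time of 72 h, tested at 1 uM (on this read-out higher numbers stand for more inhibition at the one concentration tested (going by the name of the read-out) and lower numbers for less inhibition), compound 1 gives 0%. Compound 2 `COc1ccc(C)cc1N1C(=O)CSC1c1cccc(C(=O)NCCCCc2ccccc2)c1` instead carries an amide bearing a phenylbutyl chain and a 2-methoxy-5-methylphenyl on the ring nitrogen; in this assay compound 2 gives 95%, the highest of the two numbers shown, and the gap to compound 1 lies beyond the scatter. Since the two compounds differ in more than one place, the gap cannot be assigned to any single change.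

Compound 3 `COc1c(F)cccc1N1C(=O)CSC1c1cccc(C(=O)NCCCCc2ccccc2)c1` keeps the amide and the phenylbutyl chain of compound 2 and changes only the group on the amide-type nitrogen in the ring: 3-fluoro-2-methoxyphenyl in place of 2-methoxy-5-methylphenyl on an amide-type nitrogen in a ring. For the measured compounds named here, no measured pair isolates such a swap, so the size of the step is not known from the data. Compound 3 is expected to stay close to compound 2, with a step from compound 2 to compound 3 of about a number 10 percentage points lower from compound 2 to compound 3 (within the scatter), possibly within the scatter, with a downward lean. For compound 3 the estimated inhibition in this assay is 85%, within a range of 55% to 98%.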

Compound 3, a percentage reported as inhibition, at one concentration (the size of the read-out at that concentration, not a potency): 12%
Compound 3: middle estimate off by 73 percentage points, on the high side; measured number below the stated range.
By their numbers in this assay, from the lowest: compound 1; then compound 3; then compound 2.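

In this assay, for the compounds shown here, putting 3-fluoro-2-methoxyphenyl in place of 2-methoxy-5-methylphenyl on the amide-type nitrogen in the ring gives a number 83 percentage points lower from compound 2 to compound 3 (beyond the scatter), and this pair is the first that differs in one place only. With the amide and the phenylbutyl chain held constant, the result shows that the read-out depends strongly on this aryl group, even though the entering and leaving groups have the same number of heavy atoms, the same number of hydrogen-bond acceptors and no net charge, so these counts do not separate them. Nothing measured here explains the size of this step.

The compounds shown leave open whether the step follows the loss of the methyl group, the arrival of the fluorine or the two together, and a plain 2-methoxyphenyl on the ring nitrogen alongside the same amide and phenylbutyl chain would help to separate these. Also open, going by these compounds, is whether a chlorine in place of the fluorine, or a longer chain in place of the phenylbutyl chain, would keep compound 3 at its low level or bring the read-out back towards that of compound 2.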